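The source may report more compounds than this note shows. Statements on the series, on what has been measured and on what is new or still open speak of the compounds shown alone.

Series notes. The shared core carries a substituted phenyl on an amide-type nitrogen, and that phenyl is the only part varied. Compound 1 `Cc1cc(NC(=O)Nc2ccc(N)cc2)c2ccccc2n1` bears 4-aminophenyl there. In an ADME assay on Raji cells (Homo sapiens) for cytotoxicity, with a stated time of 72 h (on this read-out higher numbers stand for an effect only at larger amounts of compound and lower numbers for an effect already at smaller amounts), compound 1 gives > 25000 nM, which is a limit of the assay and not a number. Compound 2 `Cc1cc(NC(=O)Nc2ccccc2F)c2ccccc2n1` gives > 25000 nM in this assay, again a limit. Compound 3 `Cc1cc(NC(=O)Nc2cccc(Cl)c2)c2ccccc2n1` gives 18000 nM in this assay. The steps read a step that the two limits leave unreadable from compound 1 to compound 2 and an at least 1.3-fold lower number from compound 1 to compound 3 (0.14 log units; that floor lies within the scatter), and the step of an at least 1.3-fold lower number from compound 2 to compound 3 (0.14 log units; that floor lies within the scatter) likewise has its floor inside the scatter. Note the limit of > 25000 nM in this assay, at which 2 of the 3 values shown sit: the range explored so far is narrow and mostly unresolved. Compound 4 `Cc1cc(NC(=O)Nc2ccc(N(C)C)cc2)c2ccccc2n1` is the next member. (dimethylamino in place of amino on an aromatic carbon). For the measured compounds named here, no measured step touches the amino group itself; the changes seen so far swap the whole phenyl substitution pattern, and none produced a readable step beyond the scatter. For compound 4 the step is expected to be a number no higher from compound 1 to compound 4 (the limit leaves the size open). Compound 4 is therefore estimated at 25000 nM, within 10000 nM to 60000 nM, with a limit again the likelier outcome.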

Compound 4, half-maximal effective concentration: > 25000 nM
Compound 4: no number, only a limit; the forecaster's own chance of this, stated with the estimate: 60%; the middle value lies on the limit itself.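

Compound 1 and compound 4 both end at a limit of the assay, so no step can be read between them: the limit of > 25000 nM in this assay, at which 3 of the 4 values shown sit. The compounds shown leave open whether dimethylamino in place of amino on an aromatic carbon alters the read-out in this assay at all.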